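From 4-hydroxyphenyl to 2-hydroxyphenyl in compound 4

The source may report more compounds than this note shows. Statements on the series, on what has been measured and on what is new or still open speak of the compounds shown alone.

- compound 1 `CC1(C)[C@H]2CC[C@]1(C)N(Cc1cn(-c3cccc(C#N)c3)nn1)C(=O)C2` gives 230 nM
- compound 2 `COc1ccccc1-n1cc(CN2C(=O)C[C@@H]3CC[C@@]2(C)C3(C)C)nn1` gives 140 nM
- compound 3 `CC1(C)[C@H]2CC[C@]1(C)N(Cc1cn(-c3ccc(O)cc3)nn1)C(=O)C2` gives 410 nM

All three values come from a functional assay on OVCAR-3 cells (Homo sapiens) for inhibition, read by MTT assay, with a stated time of 24 h; a lower number here means a stronger inhibitor, a higher number a weaker inhibitor. Among them, the data show a 1.8-fold higher number from compound 1 to compound 3 (0.25 log units; within the scatter), so compound 3 cannot be told apart from compound 1. They also show a 2.9-fold higher number from compound 2 to compound 3 (0.47 log units; beyond the scatter), so compound 3 is separated only from compound 2, which is the stronger inhibitor of that pair.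

Compound 4 `CC1(C)[C@H]2CC[C@]1(C)N(Cc1cn(-c3ccccc3O)nn1)C(=O)C2` keeps the shared core and has 2-hydroxyphenyl in place of 4-hydroxyphenyl on an aromatic nitrogen. Within the data shown here, no measured pair isolates this change. The closest guide is compound 2, which carries 2-methoxyphenyl and gives 140 nM, though it is not the same group. That supports only a cautious expectation of a move towards compound 2 in this assay, probably not beyond the scatter. The expected step is a 1.6-fold lower number from compound 3 to compound 4 (0.21 log units; within the scatter). Compound 4 is estimated at 250 nM, with an expected range from 110 nM to 550 nM.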

Compound 4, half-maximal inhibitory concentration: 90 nM
Estimate against measurement, compound 4: 2.8-fold (0.44 log units) above; measured number below the stated range.
By their numbers in this assay, from the lowest: compounds 4, 2, 1 and 3 (each within the scatter of the next, the first and the last beyond it).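

In this assay, shifting the hydroxyl from 4-hydroxyphenyl to 2-hydroxyphenyl, with the same atoms joined differently, gives a 4.6-fold lower number from compound 3 to compound 4 (0.66 log units; beyond the scatter), so on this aromatic nitrogen the place of the hydroxyl on the phenyl ring matters, not only its presence. A methyl on that oxygen makes no clear difference, at a 1.6-fold lower number from compound 2 to compound 4 (0.19 log units; within the scatter), while 2-hydroxyphenyl in place of 3-cyanophenyl gives a 2.6-fold lower number from compound 1 to compound 4 (0.41 log units; beyond the scatter), a separation that 4-hydroxyphenyl did not show. Nothing available here accounts for the difference between the two hydroxyphenyl groups.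

Going by these compounds, whether an amine or a carboxylic acid in place of the hydroxyl of 2-hydroxyphenyl would keep the number of compound 4 stays open. Also open, on these data alone, is where 3-hydroxyphenyl would fall relative to the two hydroxyphenyl groups.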